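Salicylanilide Cytotoxicity: Nitro in Place of Trifluoromethyl

The compounds below may be only part of what the source reports. "The series", "measured", "known", "first", "only" and "open" are said of these compounds alone.

Three anilides sharing one core have been measured in a functional assay on Jurkat cells (Homo sapiens) for cytotoxicity, read by luminescence and CellTiter-Glo, with a stated time of 3 days; on this read-out higher numbers stand for weaker inhibition and lower numbers for stronger inhibition. Compound 1 `O=C(Nc1ccc(C(F)(F)F)cc1)c1cc(Br)ccc1O` gives 620 nM in this assay, compound 2 `O=C(Nc1ccc(OC(F)(F)F)cc1)c1cc(F)ccc1O` gives 810 nM, and compound 3 `O=C(Nc1ccc(C(F)(F)F)cc1)c1cc(F)ccc1O` gives 580 nM. Compound 3 thus stands lowest of the three numbers, but a 1.1-fold lower number from compound 1 to compound 3 (0.03 log units; within the scatter) and a 1.4-fold lower number from compound 2 to compound 3 (0.15 log units; within the scatter), so no ordering among them can be claimed.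

Compound 4 `O=C(Nc1ccc([N+](=O)[O-])cc1)c1cc(F)ccc1O` is yet to be measured. It differs from compound 3 by nitro in place of trifluoromethyl on an aromatic carbon. The step from compound 2 to compound 3 bears most directly on this change, since it too exchanges one group for another on that same aromatic carbon, and it stayed within the scatter; the step from compound 1 to compound 3, on the other ring, likewise stayed within the scatter. Neither of the measured exchanges moved this assay beyond its noise, so a step of similar, modest size is expected here, with no clear direction.

On this basis compound 4 is expected to give 700 nM in this assay, with a likely range from 250 nM to 2000 nM. The estimated step is a 1.2-fold higher number from compound 3 to compound 4 (0.08 log units; within the scatter).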

Compound 4, half-maximal inhibitory concentration: 940 nM
Compound 4: middle estimate off by 1.3-fold (0.13 log units), on the low side, within the range that was stated.
By their numbers in this assay, from the lowest: compounds 3, 1, 2 and 4 (each within the scatter of the next).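

In this assay the change from trifluoromethyl to nitro, on an aromatic carbon para to a large group, gives a 1.6-fold higher number from compound 3 to compound 4 (0.21 log units; within the scatter) and so does not separate these two groups at this position. The change from trifluoromethoxy to nitro at the same place gives a 1.2-fold higher number from compound 2 to compound 4 (0.06 log units; within the scatter) and likewise separates nothing, so the three groups seen here, trifluoromethyl, trifluoromethoxy and nitro, cannot be told apart on this read-out, at least with fluoro held constant on the other ring. Nitro differs from the two groups it is compared with in having no fluorine and in the count of hydrogen-bond acceptors, yet no step beyond the scatter comes with that exchange, and no measurement that could explain the result is available.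

The compounds shown leave open whether a group of a different kind at this place, such as an amine, a carboxylic acid or a longer chain, would move the number beyond the scatter. They also leave open whether nitro would give a similar result with bromo in place of fluoro on the other ring.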